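Series notes: amine headgroup swap on the shared core

This account rests on a few compounds, and the source may have more. Where it says the series, first, only, none or still open, it means among the compounds named here.

Three compounds of the series have numbers in an assay on CHO cells for displacement of a labelled ligand from 5-hydroxytryptamine receptor 1D (Homo sapiens); on this read-out higher numbers stand for weaker inhibition and lower numbers for stronger inhibition. Compound 1 `c1ccc(CNC2CCN(CCCc3c[nH]c4ccc(-n5cnnc5)cc34)CC2)cc1` gives 4.6 nM in this assay. Compound 2 `COC[C@H](NC1CCN(CCCc2c[nH]c3ccc(Cn4cncn4)cc23)CC1)c1ccc(F)cc1` gives 5 nM in this assay, a number that sits within the scatter of the number for compound 1. Compound 3 `CC(=O)Nc1ccc([C@H](C)NCC2CCN(CCCc3c[nH]c4ccc(-n5cnnc5)cc34)CC2)cc1` gives 0.6 nM in this assay, a number that lies beyond the scatter below the number for compound 1. Compound 1 therefore stands with the second highest number of the three, close to compound 2 and well above compound 3.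

The step under consideration goes from compound 1 to compound 4 `CN(Cc1ccco1)C1CCN(CCCc2c[nH]c3ccc(-n4cnnc4)cc23)CC1`, which has not yet been measured in this assay. The change is ((furan-2-yl)methyl)(methyl)amino in place of benzylamino on a saturated ring carbon. The benzylamino group leaves and the ((furan-2-yl)methyl)(methyl)amino group enters on a saturated ring carbon of the six-membered non-aromatic ring with one nitrogen, three ring bonds from the ring nitrogen.

Going by the values given here, no measured pair in the set differs in this one place, so nothing measured speaks to the size of the step. The step is expected to be small, at most slightly toward a higher number, and possibly none beyond the scatter, as a 1.7-fold higher number from compound 1 to compound 4 (0.24 log units; within the scatter). Compound 4 is expected to give about 8 nM in this assay, with a range from 2.5 nM to 25 nM.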

Compound 4, half-maximal inhibitory concentration: 9.3 nM
For compound 4 the middle estimate is 1.2-fold (0.07 log units) below the measured one; the range from low to high includes it.
By their numbers in this assay, from the lowest: compound 3; then compounds 1, 2 and 4 (each within the scatter of the next, the first and the last beyond it).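

In this assay, going by these compounds alone, the first measured change at this saturated ring carbon gives a 2.0-fold higher number from compound 1 to compound 4 (0.31 log units; beyond the scatter), a modest step just past the scatter. The entering ((furan-2-yl)methyl)(methyl)amino group keeps the 8 heavy atoms of benzylamino, but it has a five-membered aromatic ring with 1 hetero atom in place of a six-membered aromatic ring of carbon only, and 0 hydrogen-bond donors against 1, so this one step carries both differences together. Nothing measured here accounts for the direction or size of the step, and no supporting data bear on it.

On these data alone, the share of the step that belongs to the ring exchange and the share that belongs to the added methyl on the amine remain open: benzyl(methyl)amino and ((furan-2-yl)methyl)amino on the same core would separate the two. Compound 2 and compound 3 differ from compound 1 in more than one place, so they do not settle this question, and how far a single change at this ring carbon can move the number also stays unresolved.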